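The source may hold more compounds than are shown below. What is called first, only, known or untested is meant among the compounds shown, and "the series" means these compounds.

Working notes on the series. In a functional assay on C8166 cells (Homo sapiens) for cytotoxicity, read by MTT assay (on this read-out lower numbers stand for higher toxicity in this test and higher numbers for lower toxicity in this test), compound 1 (`Cc1ccc(C(=O)Nc2cc(Cl)ccc2OCC(=O)Nc2ccc(S(N)(=O)=O)cc2C)cc1`) gives 54200 nM and compound 2 (`Cc1cc(S(N)(=O)=O)ccc1NC(=O)COc1ccc(Cl)cc1NC(=O)c1ccccc1[N+](=O)[O-]`) gives 54800 nM. Among the measured compounds shown here, these two values lie within the scatter of each other, so compound 2 stands level with the only other measured member of the series.

Compound 3 (`Cc1cc(S(N)(=O)=O)ccc1NC(=O)COc1ccc(Cl)cc1NC(=O)c1cccc([N+](=O)[O-])c1`) keeps the same atoms as compound 2, joined differently, with 3-nitrophenyl in place of 2-nitrophenyl on a carbonyl carbon.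

For the measured compounds named here, only one measured step bears on this change. The exchange of 4-methylphenyl for 2-nitrophenyl on the same carbonyl carbon, a 1.0-fold higher number from compound 1 to compound 2 (0.00 log units; within the scatter), stays within the scatter. Going by the values given here, that step replaces one group with another, and no measured pair yet tests the move from 2-nitrophenyl to 3-nitrophenyl, so the evidence is thin. Even so, nothing measured points to a shift in either direction in this assay. The expected step, a 1.0-fold lower number from compound 2 to compound 3 (0.01 log units; within the scatter), does not go beyond the scatter. For compound 3 the estimated value is 54000 nM, with an expected range of 27000 nM to 108000 nM.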

Compound 3, half-maximal cytotoxic concentration: 58800 nM
For compound 3 the middle estimate is 1.1-fold (0.04 log units) below the measured one; low and high end bracket the measured number.
By their numbers in this assay, from the lowest: compounds 1, 2 and 3 (each within the scatter of the next).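

Among the compounds shown here, the first direct comparison of the two nitrophenyl groups on this carbonyl carbon, with 3-nitrophenyl in place of 2-nitrophenyl, gives a step within the scatter in this assay (a 1.1-fold higher number from compound 2 to compound 3 (0.03 log units; within the scatter)), so this test does not separate the two isomeric groups. The exchange of 4-methylphenyl for 3-nitrophenyl at the same place (a 1.1-fold higher number from compound 1 to compound 3 (0.04 log units; within the scatter)) also stays within the scatter, and the three compounds therefore stand level across all three aryl groups shown on this carbonyl carbon. Nothing available explains this level result.

Still open, going by these compounds, is whether this position stays as flat with a group of a different kind, such as 4-nitrophenyl, an aminophenyl or carboxyphenyl group, or a plain alkyl chain in place of the aromatic ring. The three compounds also differ only at this one place, so they say nothing about how changes elsewhere on the shared core, such as replacing the chlorine or the sulfonamide, would affect the read-out in this assay.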